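This account rests on a few compounds, and the source may have more. Where it says the series, first, only, none or still open, it means among the compounds named here.

Working notes on the series. Compound 1 `Cc1cc(O)c(C(C)C)cc1-c1cc(-c2ccccc2)c(C#N)c(=O)[nH]1` gives 29% in a functional assay for inhibition, tested at 40 ug/mL; a higher number here means a stronger effect of the compound at the concentration tested, a lower number a weaker effect. Among the measured compounds shown here, compound 2 `COc1ccc(-c2cc(-c3cc(C(C)C)c(O)cc3C)[nH]c(=O)c2C#N)cc1` gives 35% in this assay; the one measured step, a number 6 percentage points higher from compound 1 to compound 2 (within the scatter), is within the scatter, so compound 2 stands at the higher of the two numbers without being separable from compound 1.

Compound 3 `COc1cc(-c2cc(-c3cc(C(C)C)c(O)cc3C)[nH]c(=O)c2C#N)ccc1O` is the next member; it differs from compound 2 by 4-hydroxy-3-methoxyphenyl in place of 4-methoxyphenyl on an aromatic carbon. For the measured compounds named here, the only step that bears on a change at this place is a number 6 percentage points higher from compound 1 to compound 2 (within the scatter), and that step was within the scatter; no measured step shows what a hydroxyl added to this ring does in this assay. The expectation is therefore a step of about no change at the digits printed from compound 2 to compound 3 (within the scatter), not beyond the scatter. For compound 3 the estimate in this assay is 35%, with a range from 20% to 50%.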

Compound 3, a percentage reported as inhibition, at one concentration (the size of the read-out at that concentration, not a potency): 32%
Compound 3: the middle estimate sits 3 percentage points above what was measured; the measured number falls inside the stated range.
By their numbers in this assay, from the lowest: compounds 1, 3 and 2 (each within the scatter of the next).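

In this assay the change from 4-methoxyphenyl to 4-hydroxy-3-methoxyphenyl gives a number 3 percentage points lower from compound 2 to compound 3 (within the scatter), and the change from phenyl to the same group gives a number 3 percentage points higher from compound 1 to compound 3 (within the scatter). The place opposite the ring nitrogen now holds phenyl, 4-methoxyphenyl and 4-hydroxy-3-methoxyphenyl, and the gain of a hydrogen-bond donor on this ring separates none of the three from the others in this assay. No evidence bears on this result.

The compounds shown leave open whether a hydroxyl or a methoxy acts alone at the position it holds in 4-hydroxy-3-methoxyphenyl, since the two enter together in compound 3. They also leave open whether a group of another kind on this ring, such as a carboxylic acid, an amine or a longer alkoxy chain, would give a step beyond the scatter.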